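Ethyl to isopropyl: expectations for compound 3

The compounds below may be only part of what the source reports. "The series", "measured", "known", "first", "only" and "open" are said of these compounds alone.

Compound 1 `CCc1cccc2ccc(-c3ccc(C(/C=C4\OC(=O)NC4=O)(CC)CC)c(=O)[nH]3)cc12` gives 1.77 h here
Compound 2 `Cc1cc(C(/C=C2\OC(=O)NC2=O)C(C)C)c(=O)[nH]c1-c1ccc2cccc(F)c2c1` gives > 3 h as a limit of the assay

Going by the values given here, in an ADME assay on microsomes from liver (Rattus norvegicus) for metabolic stability (on this read-out lower numbers stand for a shorter-lived compound and higher numbers for a longer-lived compound), compound 1 gives 1.77 h and holds the only actual number so far. Compound 2 stands at > 3 h and this is a limit, not a number.

Compound 3 `CCC(/C=C1\OC(=O)NC1=O)(CC)c1ccc(-c2ccc3cccc(C(C)C)c3c2)[nH]c1=O` is still unmeasured. The change from compound 1 to compound 3 is methyl in place of hydrogen on a saturated chain carbon bound to an aromatic carbon and a saturated chain carbon and, cut one bond further out, it reads ethyl to isopropyl. Among the compounds with values here, no measured pair of compounds shows what such a change does, so in this assay no step beyond the usual scatter is expected, in either direction. The estimated 1.1-fold lower number from compound 1 to compound 3 (0.04 log units; within the scatter) therefore stays small. For compound 3 an expected value of 1.6 h is estimated, with 0.8 h to 3.2 h as the expected range.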

Compound 3, half-life: 1.88 h
Compound 3: middle estimate off by 1.2-fold (0.07 log units), on the low side; the measured number falls inside the stated range.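

In this assay, going by these compounds alone, the first pair of measured compounds that differ in one place gives a 1.1-fold higher number from compound 1 to compound 3 (0.03 log units; within the scatter). Methyl in place of hydrogen on a saturated chain carbon bound to an aromatic carbon and a saturated chain carbon, which also reads as ethyl to isopropyl, thus leaves the half-life within the usual scatter on this core. Neither compound 1 nor compound 3 sits at the limit of the assay, so this step is read between two actual numbers: the limit of > 3 h in this assay, at which 1 of the 3 values shown sits.

On these data alone, whether this position would stay as flat with a longer chain, an amine or a carboxylic acid in that place remains open. Within the data shown here, compound 2, with a value of > 3 h that is a limit of the assay and not a number, differs in more than one place and offers no second step to set beside this one.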